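Tert-butyl in place of propyl on a diaryl urea

The source may hold more compounds than are shown below. What is called first, only, known or untested is meant among the compounds shown, and "the series" means these compounds.

Compound 1 `CCCc1ccc(NC(=O)Nc2c(C(C)C)cccc2C(C)C)cc1`: 38 nM
Compound 2 `CCCCCCc1ccc(NC(=O)Nc2c(C(C)C)cccc2C(C)C)cc1`: 26 nM

Among the measured compounds shown here, in an assay on isolated protein for inhibition of acyl-CoA:cholesterol acyltransferase (Oryctolagus cuniculus) (on this read-out higher numbers stand for weaker inhibition and lower numbers for stronger inhibition), compound 1 gives 38 nM, one of only two numbers measured, and compound 2 gives 26 nM, so that a 1.5-fold lower number from compound 1 to compound 2 (0.16 log units; within the scatter) stays within the scatter. Compound 3 `CC(C)c1cccc(C(C)C)c1NC(=O)Nc1ccc(C(C)(C)C)cc1` differs from compound 1 by tert-butyl in place of propyl on an aromatic carbon. For the measured compounds named here, the single step that bears on this place, a 1.5-fold lower number from compound 1 to compound 2 (0.16 log units; within the scatter), was small, so for compound 3 the expected change is no more than the scatter, namely a 1.1-fold lower number from compound 1 to compound 3 (0.04 log units; within the scatter). Compound 3 is therefore estimated at 35 nM, with a range from 15 nM to 90 nM.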

Compound 3, half-maximal inhibitory concentration: 168 nM
Compound 3: middle estimate off by 4.8-fold (0.68 log units), on the low side; the measured number lies above the stated range.
By their numbers in this assay, from the lowest: compounds 2 and 1 (each within the scatter of the next); then compound 3.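

On this aromatic carbon in this assay, the group matters more than the earlier pair suggested: tert-butyl in place of propyl gives a 4.4-fold higher number from compound 1 to compound 3 (0.65 log units; beyond the scatter), and tert-butyl in place of hexyl gives a 6.5-fold higher number from compound 2 to compound 3 (0.81 log units; beyond the scatter). Propyl and hexyl had stayed within the scatter of each other, so only the change to tert-butyl moves the number beyond it. Nothing measured here accounts for this difference.

Going by these compounds, whether the weaker inhibition belongs to tert-butyl alone or extends to other branched groups, such as isopropyl, remains open. So does the effect of an amine or a carboxylic acid on this carbon.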